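The compounds below may be only part of what the source reports. "The series", "measured", "known", "first", "only" and "open" are said of these compounds alone.

Compound 2 `CCOc1ccc(C(=O)Nc2cc3nc(C4CCCCC4)[nH]c3cc2N(CC)CC)cc1` is one of two compounds in this set, the other being compound 1 `CCN(CC)c1cc2[nH]c(C3CCCCC3)nc2cc1NC(=O)c1ccc(N(C)C)cc1`, for which an ADME assay on Vero cells (Chlorocebus sabaeus) for cytotoxicity, read by resazurin assay, with a stated time of 3 days (on this read-out lower numbers stand for stronger inhibition and higher numbers for weaker inhibition), gives "not determined" (no result reported). In this assay compound 2 reaches only the limit of the measurement, > 100 ug/mL. This is the position described by the limit of > 100 ug/mL in this assay, at which 1 of the 2 values shown sits. Compound 3 `CCCNC(=O)Nc1cc2nc(C3CCCCC3)[nH]c2cc1N(CC)CC` differs from compound 2 by propylamino in place of 4-ethoxyphenyl on a carbonyl carbon. Within the data shown here, no measured step of this kind is available, so no direction beyond the scatter is expected. Compound 3 is estimated at 150 ug/mL, within 50 ug/mL to 500 ug/mL, in this assay. The expected step that the limit leaves unreadable from compound 2 to compound 3 is therefore small.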

Compound 3, half-maximal inhibitory concentration: > 100 ug/mL
Compound 3: a limit, no number; the forecaster's own chance of this, stated with the estimate: 75%; the middle value does not contradict the limit.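

No new step can be read between compound 2 and compound 3 in this assay, since both results are limits and not numbers. The compounds shown leave open whether propylamino in place of 4-ethoxyphenyl on a carbonyl carbon changes this read-out at all.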